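The compounds below may be only part of what the source reports. "The series", "measured", "known", "first", "only" and "open" are said of these compounds alone.

Measured so far in an assay on LM cells for displacement of a labelled ligand from Neuropeptide Y receptor type 5 (Homo sapiens); a higher number here means a weaker inhibitor, a lower number a stronger inhibitor:
compound 1 `Fc1ccc(C2(c3ccc(F)cc3)CNC(c3cccc(C(F)(F)F)c3)=N2)cc1` gives 6.2 nM
compound 2 `Fc1ccc(C2(c3ccc(F)cc3)CNC(c3cccc(F)c3)=N2)cc1` gives 10 nM
compound 3 `O=Cc1cccc(C2=NC(c3ccc(F)cc3)(c3ccc(F)cc3)CN2)c1` gives 8.7 nM

Compound 1 stands at the lowest of the three numbers shown, but the steps of a 1.6-fold higher number from compound 1 to compound 2 (0.21 log units; within the scatter) and a 1.4-fold higher number from compound 1 to compound 3 (0.15 log units; within the scatter) are both within the scatter, so no order among compounds 1, 2 and 3 is established.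

Compound 4 `OCc1cccc(C2=NC(c3ccc(F)cc3)(c3ccc(F)cc3)CN2)c1` is not yet measured. It differs from compound 1 in one place: hydroxymethyl in place of trifluoromethyl on an aromatic carbon. Within the data shown here, the steps that bear on it are the two earlier exchanges of the trifluoromethyl, a 1.6-fold higher number from compound 1 to compound 2 (0.21 log units; within the scatter) and a 1.4-fold higher number from compound 1 to compound 3 (0.15 log units; within the scatter), each within the scatter. A further group at the same position is therefore expected to give no step beyond the scatter in this assay. Compound 4 is estimated at 9 nM, range 4 nM to 25 nM. The expected step is a 1.5-fold higher number from compound 1 to compound 4 (0.16 log units; within the scatter).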

Compound 4, half-maximal inhibitory concentration: 59 nM
Estimate against measurement, compound 4: 6.6-fold (0.82 log units) below; the measured number lies above the stated range.
By their numbers in this assay, from the lowest: compounds 1, 3 and 2 (each within the scatter of the next); then compound 4.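

In this assay, this aromatic carbon is not indifferent to its substituent. Hydroxymethyl gives a 9.5-fold higher number from compound 1 to compound 4 (0.98 log units; beyond the scatter), a 6.8-fold higher number from compound 3 to compound 4 (0.83 log units; beyond the scatter) and a 5.9-fold higher number from compound 2 to compound 4 (0.77 log units; beyond the scatter), all beyond the scatter, whereas trifluoromethyl, fluoro and formyl remain within the scatter of one another. Unlike trifluoromethyl, hydroxymethyl carries a hydrogen-bond donor and a hydrogen-bond acceptor, but this count alone does not explain the step.

No measurement at hand accounts for the loss. On these data alone, whether methoxymethyl, aminomethyl or a carboxylic acid here would track hydroxymethyl or the other three groups remains open.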